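This account rests on a few compounds, and the source may have more. Where it says the series, first, only, none or still open, it means among the compounds named here.

Compound 1 `COc1ccccc1-c1cc(CN(C)C)ccc1Cl` gives 11% in a functional assay on HEK293 cells for agonist activity at 5-hydroxytryptamine receptor 7 (Homo sapiens), read by cAMP accumulation, with a stated time of 30 min; a higher number here means a larger maximal response, a lower number a smaller maximal response. Compound 2 `CCN(CC)Cc1ccc(Cl)c(-c2ccccc2OC)c1` was reported in this assay as "not active" (no number reported), so no number stands for it; where it stands can only be described as yielding no recorded response, while compound 1 yielded a recorded value. The step to compound 3 `COc1ccccc1-c1cc(C2CCN(C)C2)ccc1Cl` changes one group: 1-methylpyrrolidin-3-yl in place of (diethylamino)methyl on an aromatic carbon. Among the compounds with values here, no measured pair shows this exchange, so its size in this assay cannot be read from the data. Given that compound 2 gave "not active" (no number reported) and compound 1 gave 11%, any move is expected to stay small, with no direction beyond the scatter that can be argued for. Compound 3 is therefore expected to give about 12% in this assay, with an estimated range from 0% to 35%, and a fair chance that again no number is reported.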

Compound 3, largest response reached (Emax), in percent of the reference or control that the assay uses: 9.8%
Compound 3: the middle estimate sits 2.2 percentage points above what was measured; measured number inside the range.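

In this assay, 1-methylpyrrolidin-3-yl in place of (dimethylamino)methyl on this aromatic carbon gives a number 1.2 percentage points lower from compound 1 to compound 3 (within the scatter), so a five-membered non-aromatic ring can stand at this position with no change in maximal response beyond the scatter. The exchange of (diethylamino)methyl for the same ring cannot be read as a step, since compound 2 has no number, and the data therefore cannot tell whether compound 3 differs from it. Nothing available bears on the reason for this result.

The compounds shown leave open whether any group at this position can raise the response well beyond the low values seen so far, for example a piperidin-4-yl ring, a primary amine or a longer chain carrying the amine. They also leave open whether a fluoro group in place of the chloro group would alter the response.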